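Hydroxy for fluoro on compound 1: an expectation

A few compounds are considered here, and "the series" means these few. Any claim that something is new, unique, unknown or untested is made for them only; others in the source may bear on it.

Measured so far:
- Compound 1 `C=C1[C@@H](OC(C)=O)C[C@@H]2[C@](C)(CO[Si](C)(C)C(C)(C)C)[C@H](OC(C)=O)CC[C@@]2(C)[C@@H]1C[C@@H](Nc1ccc(F)cc1)C1=CCOC1=O` gives 4340 nM in a functional assay on MCF7 cells (Homo sapiens) for cytotoxicity, read by sulforhodamine B assay; on this read-out higher numbers stand for weaker inhibition and lower numbers for stronger inhibition.
- Compound 2 `C=C1[C@@H](OC(C)=O)C[C@@H]2[C@](C)(COC=O)[C@H](OC(C)=O)CC[C@@]2(C)[C@@H]1C[C@@H](Nc1ccc(F)cc1)C1=CCOC1=O` gives 12400 nM in this assay.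

Compound 1 stands at the lowest of the two numbers; its nearest neighbour is compound 2, reached by a 2.9-fold higher number from compound 1 to compound 2 (0.46 log units; beyond the scatter). That single measured step concerns the group on the oxygen on a saturated carbon and leaves the aromatic ring untouched.

Compound 3 `C=C1[C@@H](OC(C)=O)C[C@@H]2[C@](C)(CO[Si](C)(C)C(C)(C)C)[C@H](OC(C)=O)CC[C@@]2(C)[C@@H]1C[C@@H](Nc1ccc(O)cc1)C1=CCOC1=O` differs from compound 1 by hydroxy in place of fluoro on an aromatic carbon. Among the measured compounds shown here, no measured step bears on this change: neither measured compound varies at the aromatic ring, so nothing shows how this assay responds there. With no guide from the measured pairs, the expectation for compound 3 is a step of a 1.2-fold higher number from compound 1 to compound 3 (0.06 log units; within the scatter), that is, none beyond the scatter, with wide uncertainty. Compound 3 is therefore estimated at 5000 nM, in a range from 1500 nM to 16000 nM.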

Compound 3, half-maximal inhibitory concentration: 5220 nM
The estimate for compound 3 lay 1.0-fold (0.02 log units) below the measured number; measured number inside the range.
By their numbers in this assay, from the lowest: compounds 1 and 3 (each within the scatter of the next); then compound 2.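

In this assay, among the compounds shown here, the first look at the aromatic ring gives a 1.2-fold higher number from compound 1 to compound 3 (0.08 log units; within the scatter) for hydroxy in place of fluoro. At this carbon, para to a large group, the exchange therefore produces no change beyond the scatter, even though the entering hydroxy carries a hydrogen-bond donor and a hydrogen-bond acceptor and the leaving fluoro carries neither. No supporting data bear on why the number holds here.

From the compounds shown here alone, this is a single exchange on a single background, so it remains open whether the same exchange would behave alike on compound 2. Also open, going by these compounds, is whether a larger or charged group at this place on the ring, such as a methoxy group, an amine or a carboxylic acid, would leave the number in this assay equally unmoved.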